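A few compounds are considered here, and "the series" means these few. Any claim that something is new, unique, unknown or untested is made for them only; others in the source may bear on it.

Compound 1 `Nc1scc(CN2CCN(c3cc(Cl)cc(Cl)c3)CC2)c1C(=O)c1ccc(Cl)cc1` gives -1% in a functional assay on CHO cells with adenosine receptor A1 (Homo sapiens) as the target, read by cAMP accumulation and immunoassay, with a stated time of 6 min, tested at 0.01 uM (a higher number here means a weaker effect of the compound at the concentration tested, a lower number a stronger effect), and compound 2 `Nc1scc(CN2CCN(c3c(F)cc(F)cc3F)CC2)c1C(=O)c1ccc(Cl)cc1` gives 4.2% in this assay. Within the data shown here, compound 2 stands highest of the two numbers, but its only neighbour is compound 1, and the step of a number 5.2 percentage points higher from compound 1 to compound 2 (within the scatter) lies within the scatter. Compound 3 `Nc1scc(CN2CCN(CCCc3ccc(Cl)cc3)CC2)c1C(=O)c1ccc(Cl)cc1` carries the change (3-(4-chlorophenyl)propyl in place of 2,4,6-trifluorophenyl on an amine nitrogen in a ring). Among the measured compounds shown here, the one measured step swapped one aromatic ring for another; none swaps a ring for a chain, so it bears only weakly. The expected step of a number 0.8 percentage points higher from compound 2 to compound 3 (within the scatter) is therefore none beyond the scatter. Compound 3 is estimated at 5%, within -12% to 25%.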

Compound 3, a percentage reported as activity, at one concentration (the size of the read-out at that concentration, not a potency): 0%
Compound 3: middle estimate off by 5 percentage points, on the high side; the measured number falls inside the stated range.
By their numbers in this assay, from the lowest: compounds 1, 3 and 2 (each within the scatter of the next).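

With 3-(4-chlorophenyl)propyl on the amine nitrogen in the ring, the read-out in this assay shows a number 4.2 percentage points lower from compound 2 to compound 3 (within the scatter) and a number 1 percentage points higher from compound 1 to compound 3 (within the scatter). At this position, then, a chain carrying the ring gives a number that cannot be told apart from those of the two groups without a chain, even though the chlorine count and pattern also differ. No measurement at hand explains this result.

Still open, as far as these compounds go, is whether a shorter benzyl group, or a group with no aromatic ring, such as methyl or a carboxylic acid, would hold the number. A single concentration also cannot show whether the potencies of these compounds differ.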